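A second chloro, tried on a second core

The source may report more compounds than this note shows. Statements on the series, on what has been measured and on what is new or still open speak of the compounds shown alone.

compound 1 `ClCc1cccc(Cn2cnc3c(Cl)ncnc32)c1` gives 15100 nM in a functional assay on K562 cells (Homo sapiens) for cytotoxicity, read by sulforhodamine B assay, with a stated time of 48 h; a higher number here means a weaker inhibitor of growth, a lower number a stronger inhibitor of growth
compound 2 `ClCc1cccc(Cn2cnc3c(Cl)nc(Cl)nc32)c1` reaches only a limit of this assay: > 100000 nM
compound 3 `ClCc1ccccc1Cn1cnc2ncnc(Cl)c21` gives 5880 nM in this assay

Compound 1 and compound 3 are built from the same atoms joined differently; the difference between the two cores is not broken down here. In this assay compound 3 gives the lower of the two numbers, and its gap to compound 1 lies beyond the scatter.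

Compound 2 carries one change relative to compound 1, (chloro in place of hydrogen on an aromatic carbon). That change brings an at least 6.6-fold higher number from compound 1 to compound 2 (0.82 log units; beyond the scatter), a step whose size is known only as a lower bound because compound 2 sits at the limit of > 100000 nM in this assay, at which 1 of the 3 values shown sits.

Compound 4 `ClCc1ccccc1Cn1cnc2nc(Cl)nc(Cl)c21` carries the same change on the core of compound 3, (chloro in place of hydrogen on an aromatic carbon). Within the data shown here, the single measured step of this kind weakened growth inhibition beyond the scatter, so compound 4 is expected to show a comparable loss, a 7.7-fold higher number from compound 3 to compound 4 (0.88 log units; beyond the scatter), resting on an at least 6.6-fold higher number from compound 1 to compound 2 (0.82 log units; beyond the scatter). The estimate for compound 4 in this assay is 45000 nM, ranging from 15000 nM to 150000 nM, with a real chance that only a limit is reported.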

Compound 4, concentration for total growth inhibition: 690 nM
Compound 4: the middle estimate sits 65-fold (1.81 log units) above what was measured; measured number outside the range, below it.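

Placed on the second core, the added chloro gives an 8.5-fold lower number from compound 3 to compound 4 (0.93 log units; beyond the scatter) in this assay. The same change therefore does not carry from one core to the other in these compounds, not even in direction: the same change on two cores in this assay, an at least 6.6-fold higher number (0.82 log units; beyond the scatter) from compound 1 to compound 2 and an 8.5-fold lower number (0.93 log units; beyond the scatter) from compound 3 to compound 4, at least 56-fold (1.75 log units) apart, beyond the scatter of two such steps

Each core supplies only one pair, and compound 2 stands at a limit of the assay, so the gap is known only as a lower bound, and nothing here shows which feature of the two cores separates the outcomes: the limit of > 100000 nM in this assay, at which 1 of the 4 values shown sits.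

The compounds shown leave open whether a bromo group or an amine at the place of the added chloro would split the two cores in the same way. They also leave open whether the opposite steps would persist if an amine replaced the chloro already present on each core.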